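The source may report more compounds than this note shows. Statements on the series, on what has been measured and on what is new or still open speak of the compounds shown alone.

Compound 2 `CCCCCCCCCCCCOC(=O)CCC(=O)N1CCN(CCCOc2cc3c(Nc4ccc(F)c(Cl)c4)ncnc3cc2OC)CC1` gives 5.7% in a functional assay on A549 cells (Homo sapiens) for cytotoxicity, read by MTT assay, with a stated time of 24 h, tested at 40 uM (a higher number here means a weaker effect of the compound at the concentration tested, a lower number a stronger effect), the lowest of the two numbers in hand; compound 1 `CCCCOC(=O)CCC(=O)N1CCN(CCCOc2cc3c(Nc4ccc(F)c(Cl)c4)ncnc3cc2OC)CC1` gives 79.1%. For the measured compounds named here, the only measured step, a number 73.4 percentage points lower from compound 1 to compound 2 (beyond the scatter), bears on the chain in question but is a far larger change than methyl in place of hydrogen on a saturated chain carbon, ten or more bonds along the chain from an oxygen next to a carbonyl group, which gives compound 3 `CCCCCCCCCCCCCOC(=O)CCC(=O)N1CCN(CCCOc2cc3c(Nc4ccc(F)c(Cl)c4)ncnc3cc2OC)CC1`. Going by the values given here, the same difference, cut one bond further out, reads methyl to ethyl, ethyl to propyl, propyl to butyl; no step of that size has been measured. As compound 2 already sits near the floor of the read-out, in this assay the step of a number 0.7 percentage points lower from compound 2 to compound 3 (within the scatter) is expected to stay within the scatter. Compound 3 is estimated at 5%, between 0% and 20%.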

Compound 3, a percentage reported as activity, at one concentration (the size of the read-out at that concentration, not a potency): 71.1%
For compound 3 the middle estimate is 66.1 percentage points below the measured one; measured number outside the range, above it.
By their numbers in this assay, from the lowest: compound 2; then compounds 3 and 1 (each within the scatter of the next).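

In this assay the far end of the chain proves highly sensitive: methyl in place of hydrogen on a saturated chain carbon gives a number 65.4 percentage points higher from compound 2 to compound 3 (beyond the scatter). With a number 8 percentage points lower from compound 1 to compound 3 (within the scatter), the read-out does not follow chain length across the three compounds, and compound 2 stands alone against compounds 1 and 3. No measured evidence accounts for this sensitivity.

Open, from the compounds shown here alone, is whether other chain lengths share the low read-out of compound 2, and whether a longer chain or a terminal amine keeps it.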